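The source may hold more compounds than are shown below. What is called first, only, known or untested is meant among the compounds shown, and "the series" means these compounds.

Three compounds give a first picture of this series in an assay for inhibition of protein disulfide-isomerase (Homo sapiens), with a stated time of 1 h; on this read-out lower numbers stand for stronger inhibition and higher numbers for weaker inhibition. Compound 1 `Cc1ccnc(NC(c2ccc([N+](=O)[O-])cc2)c2ccc3cccnc3c2O)c1` gives 530 nM, compound 3 `Cc1ccnc(NC(c2cccc(F)c2)c2ccc3cccnc3c2O)c1` gives 350 nM, and compound 2 `Cc1cc(C)c(C(Nc2ccccn2)c2ccc3cccnc3c2O)c(C)c1` gives 190 nM. Compound 2 therefore carries the lowest of the three numbers, but its gap to compound 3 lies within the scatter, while its gap to compound 1 lies beyond it, so compound 2 and compound 3 cannot be told apart on these data.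

The unmeasured compound 4 `Oc1c(C(Nc2ccccn2)c2c(Cl)cccc2Cl)ccc2cccnc12` differs from compound 2 in one place: 2,6-dichlorophenyl in place of 2,4,6-trimethylphenyl on a saturated chain carbon bound to an aromatic carbon and a nitrogen on an aromatic ring. Within the data shown here, the only measured step that touches the same position is the one from compound 1 to compound 3, where a 1.5-fold lower number from compound 1 to compound 3 (0.18 log units; within the scatter); that exchange of one aryl group for another on the saturated chain carbon left the read-out essentially unchanged. Nothing measured shows what 2,6-dichlorophenyl does in place of 2,4,6-trimethylphenyl, so the expectation rests on that single step and on the narrow spread of all three values.

Compound 4 is therefore expected to land close to compound 2, with a step of a 1.3-fold higher number from compound 2 to compound 4 (0.12 log units; within the scatter) that should not go beyond the scatter. The estimate for compound 4 is 250 nM, with a range from 90 nM to 700 nM.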

Compound 4, half-maximal inhibitory concentration: 1890 nM
Compound 4: middle estimate off by 7.6-fold (0.88 log units), on the low side; measured number outside the range, above it.
By their numbers in this assay, from the lowest: compounds 2, 3 and 1 (each within the scatter of the next, the first and the last beyond it); then compound 4.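

In this assay the aryl group on the saturated chain carbon proves able to move the read-out well beyond the scatter: 2,6-dichlorophenyl in place of 2,4,6-trimethylphenyl gives a 9.9-fold higher number from compound 2 to compound 4 (1.00 log units; beyond the scatter). The earlier exchange at this place, a 1.5-fold lower number from compound 1 to compound 3 (0.18 log units; within the scatter), had stayed within the scatter, so a small step there does not carry over to every aryl exchange, although the two steps start from compounds that differ elsewhere and cannot be set directly against each other. Nothing given here accounts for the size of the new step.

The compounds shown leave open whether plain phenyl or methoxyphenyl on the same saturated chain carbon would give a number nearer to that of compound 2 or to that of compound 4. They also leave open whether 2,6-dichlorophenyl would bring a step of similar size in the setting of compound 1 and compound 3, so the result rests for now on this single pair.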